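The compounds below may be only part of what the source reports. "The series", "measured", "known", "first", "only" and "open" are said of these compounds alone.

Measured compounds:
Compound 1, `CCCSc1nc(N/N=C(\C)c2ccccc2O)c2nnn(Cc3ccccc3Cl)c2n1`, in a functional assay on MGC-803 cells (Homo sapiens) for antiproliferative activity, read by MTT assay, with a stated time of 72 h; a higher number here means a weaker inhibitor, a lower number a stronger inhibitor: 35000 nM
Compound 2, `CCCSc1nc(N/N=C/c2cccc(Cl)c2)c2nnn(Cc3ccccc3)c2n1`, in this assay: > 64000 nM, which is a limit of the assay and not a number

Among the compounds with values here, compound 1 holds the only number among the two values shown. For compound 2 the assay reports only a limit, (the limit of > 64000 nM in this assay, at which 1 of the 2 values shown sits), so it gives no number to compare against.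

Compound 3, `CCCSc1nc(N/N=C(\C)c2ccccc2O)c2nnn(Cc3ccc(O)cc3)c2n1`, differs from compound 1 in one place: 4-hydroxyphenyl in place of 2-chlorophenyl on a saturated chain carbon bound to an aromatic nitrogen. Within the data shown here, no step between measured compounds is available to size this change, and compound 2 differs from compound 1 in more than one place, so its limit tells nothing about it directly. The step from compound 1 to compound 3 in this assay is therefore expected to be small, most likely within the scatter, with a modest weakening as the more probable direction, a 1.1-fold higher number from compound 1 to compound 3 (0.06 log units; within the scatter). Compound 3 is estimated at 40000 nM, between 15000 nM and 90000 nM.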

Compound 3, half-maximal inhibitory concentration: 7680 nM
Beside the measured number, compound 3's estimate is 5.2-fold (0.72 log units) above it; measured number below the stated range.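

Within the data shown here, replacing 2-chlorobenzyl with 4-hydroxybenzyl gives, in this assay, a 4.6-fold lower number from compound 1 to compound 3 (0.66 log units; beyond the scatter), the first step that can be read. It shows that, with the rest of compound 1 unchanged, the group on a saturated chain carbon bound to an aromatic nitrogen can move the number beyond the scatter, here towards a stronger inhibitor. Nothing shown bears on why the step goes in this direction.

The change swaps chlorine for hydroxyl and also differs in the substituent's place on the phenyl ring, and the compounds shown do not separate these two differences. From the compounds shown here alone, whether an amine or a carboxylic acid in place of the hydroxyl would lower the number further remains open.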